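Flipping One Ring Stereocentre in Compound 3

A few compounds are considered here, and "the series" means these few. Any claim that something is new, unique, unknown or untested is made for them only; others in the source may bear on it.

Compound 1 `CC(=O)CC/C=C(\C)CCC1=C(C)CCCC1(C)C` reaches only a limit in a functional assay on A549 cells (Homo sapiens) for inhibition; a lower number here means a stronger inhibitor of growth, a higher number a weaker inhibitor of growth: compound 1 gives > 15000 nM, which is a limit of the assay rather than a number. Compound 2 `C=C1CCCC(C)(C)C1CC[C@]1(C)CC[C@@H]([C@@H](C)C(=O)O)OO1` likewise shows only a limit, giving > 10000 nM in this assay. Going by the values given here, compound 3 `C=C1CCC[C@H]2[C@](C)(CC[C@]3(C)CC[C@@H]([C@@H](C)C(=O)O)OO3)[C@@H](C)CC[C@]12C` is the one compound with a measured number, giving 940 nM in this assay, so it stands alone as the reference point. Compound 4 `C=C1CCC[C@H]2[C@](C)(CC[C@]3(C)CC[C@H]([C@@H](C)C(=O)O)OO3)[C@@H](C)CC[C@]12C` keeps every atom and bond of compound 3; (the two compounds have the same atoms and bonds and differ only in configuration as drawn: 1 of 7 stereo elements differ; a stereocentre at a saturated ring carbon is drawn S in compound 3 and R in compound 4). Among the compounds with values here, no measured pair shows what such a change in configuration does here. The step of a 1.6-fold higher number from compound 3 to compound 4 (0.20 log units; within the scatter) is therefore expected to be modest, leaning toward weaker inhibition of growth. Compound 4 is expected to give about 1500 nM, within 400 nM to 6000 nM.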

Compound 4, concentration for 50% growth inhibition: 1450 nM
Estimate against measurement, compound 4: 1.0-fold (0.01 log units) above, within the range that was stated.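

The step here is a 1.5-fold higher number from compound 3 to compound 4 (0.19 log units; within the scatter), so drawing this saturated ring carbon as S or as R leaves no readable difference in this assay. Going by these compounds alone, none of the earlier compounds formed such a pair, and this one is a clean comparison: the fact that compounds 3 and 4 differ only in the configuration as drawn. At this stereocentre, then, either configuration keeps growth inhibition in the same range.

As far as these compounds go, whether the other stereocentres are equally forgiving stays open. So does what a methyl ester or an amide would do in place of the carboxylic acid.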